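The compounds below may be only part of what the source reports. "The series", "measured", "known", "first", "only" and "open" are said of these compounds alone.

Measured compounds:
- compound 1 `CCOC(=O)c1cc(-c2cccc(OCc3ccc(F)cc3)c2)on1` — "not determined" (no result reported)
- compound 2 `CCOC(=O)c1cc(-c2cccc(OCc3cc(F)ccc3F)c2)on1` — > 128000 nM

Compound 1 carries no result in an ADME assay on Vero cells (Chlorocebus sabaeus) for cytotoxicity, with a stated time of 72 h; a higher number here means a weaker inhibitor, a lower number a stronger inhibitor; its entry reads "not determined" (no result reported). For compound 2 this assay reports only a limit, > 128000 nM. Among the measured compounds shown here, compound 2 therefore stands at the limit of > 128000 nM in this assay, at which 1 of the 2 values shown sits, and the other entry gives no single number, so no measured step can be drawn from the data.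

Compound 3 `CCOC(=O)c1cc(-c2cccc(OCc3ccc(F)cc3F)c2)on1` is the next compound to be measured in this assay. It differs from compound 2 in one place: 2,4-difluorophenyl in place of 2,5-difluorophenyl on a saturated chain carbon bound to an oxygen on an aromatic ring. In the words of the change, 2,4-difluorophenyl takes the place of 2,5-difluorophenyl on a saturated chain carbon bound to an oxygen on an aromatic ring; both groups have the same atoms, joined differently.

For the measured compounds named here, with no measured step in hand, the expected step from compound 2 to compound 3 in this assay is none beyond the usual scatter, with the reported value likely to be another limit rather than a number. For compound 3 the estimate in this assay is 150000 nM, in the range 60000 nM to 400000 nM, which corresponds to an expected step that the limit leaves unreadable from compound 2 to compound 3.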

Compound 3, half-maximal inhibitory concentration: > 128000 nM
Compound 3: only a limit was reported; the forecaster's own chance of this, stated with the estimate: 85%; the middle value is on the limit's open side.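

No step can be read from compound 2 to compound 3 in this assay, since each gives only a limit and not a number: the limit of > 128000 nM in this assay, at which 2 of the 3 values shown sit.

The compounds shown leave open how 2,4-difluorophenyl and 2,5-difluorophenyl compare in this assay, and where the half-maximal inhibitory concentration of either compound actually lies.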